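Swapping a Sulfonamide for a Hydroxyethyl Sulfone

This account rests on a few compounds, and the source may have more. Where it says the series, first, only, none or still open, it means among the compounds named here.

Measured so far in an assay on CHO cells for displacement of a labelled ligand from prostaglandin D2 receptor 2 (Homo sapiens), read by scintillation counting; on this read-out lower numbers stand for stronger inhibition and higher numbers for weaker inhibition:
- Compound 1, `CC(C)c1ccc(S(C)(=O)=O)cc1C#Cc1cc(C#N)ccc1OCC(=O)O`, gives 12 nM
- Compound 2, `CN(c1cccc(C#Cc2cc(Cl)ccc2OCC(=O)O)c1)S(C)(=O)=O`, gives 122 nM
- Compound 3, `COCCN(C)S(=O)(=O)c1ccc(C)c(C#Cc2cc(Cl)ccc2OCC(=O)O)c1`, gives 4.1 nM

All three share a core in which two aromatic rings are joined by a carbon-carbon triple bond, one ring carrying the oxyacetic acid. Compound 3 has the lowest number of the three in this assay; compound 1 stands closest to it, with a gap that lies beyond the usual scatter, and compound 2 stands furthest away, also beyond the scatter. So compound 3 is the most potent compound measured here.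

Compound 4, `Cc1ccc(S(=O)(=O)CCO)cc1C#Cc1cc(Cl)ccc1OCC(=O)O`, has not yet been measured. It differs from compound 3 in one place: 2-hydroxyethyl in place of (2-methoxyethyl)(methyl)amino on a sulfonyl sulfur. The sulfonyl group itself stays, but the nitrogen-bearing branch gives way to a shorter chain ending in a hydroxyl.

Among the compounds with values here, no pair of measured compounds differs in exactly this way, so the step has to be guessed. The change is modest in size, and the closest comparison, compound 1 with a plain methylsulfonyl group giving 12 nM, still sits in the low range. A small weakening, or no step beyond the scatter, is the expectation, written as a 2.0-fold higher number from compound 3 to compound 4 (0.29 log units; within the scatter). Compound 4 is therefore estimated at 8 nM, with a likely range from 2.5 nM to 30 nM.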

Compound 4, inhibition constant: 19 nM
For compound 4 the middle estimate is 2.4-fold (0.38 log units) below the measured one; low and high end bracket the measured number.
By their numbers in this assay, from the lowest: compound 3; then compounds 1 and 4 (each within the scatter of the next); then compound 2.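

Replacing (2-methoxyethyl)(methyl)amino with 2-hydroxyethyl on the sulfonyl sulfur gives, in this assay, a 4.6-fold higher number from compound 3 to compound 4 (0.67 log units; beyond the scatter) and so shows that what hangs on this sulfur matters, even though the sulfonyl group itself stays in place. The step is modest rather than ruinous: compound 4 keeps a number of 19 nM and so stays well within a useful range, which means the (2-methoxyethyl)(methyl)sulfamoyl group is preferred here but is not essential for activity. No measurement is available that explains why the number rises with this change.

This single swap alters two things at once, namely the atom attached to the sulfur and the end of the chain, so the compounds shown cannot say whether the loss follows the nitrogen, the chain length or the exchange of methoxy for hydroxyl. A 2-methoxyethyl group on the same sulfur, or a (2-hydroxyethyl)(methyl)amino group, would pull these parts of the change apart.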